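A few compounds are considered here, and "the series" means these few. Any claim that something is new, unique, unknown or untested is made for them only; others in the source may bear on it.

Measured so far:
compound 1 `COc1ccc(-c2cc3nccc(-c4cc(OC)c(OC)c(OC)c4)n3n2)cc1N` — 251 nM
compound 2 `COc1cc(-c2ccnc3cc(-c4ccc(C(C)(C)C)cc4)nn23)cc(OC)c1OC` — > 10000 nM, a limit of the assay
compound 3 `COc1cc(-c2ccnc3cc(-c4ccc(N(C)C)cc4)nn23)cc(OC)c1OC` — 2050 nM
compound 4 `COc1cc(-c2ccnc3cc(-c4ccc(C)c(C)c4)nn23)cc(OC)c1OC` — not yet measured

In a functional assay on HCT-116 cells (Homo sapiens) for inhibition, read by CCK-8 assay, with a stated time of 48 h (a lower number here means a stronger inhibitor, a higher number a weaker inhibitor), compound 1 gives the lowest of the two numbers shown; the nearest is compound 3, with an 8.2-fold higher number from compound 1 to compound 3 (0.91 log units; beyond the scatter). Compound 2 reaches only a limit (the limit of > 10000 nM in this assay, at which 1 of the 3 values shown sits). The step to compound 4 is 3,4-dimethylphenyl in place of 3-amino-4-methoxyphenyl on an aromatic carbon. Going by the values given here, two measured steps bear on it: an at least 39-fold higher number from compound 1 to compound 2 (1.60 log units; beyond the scatter), where an alkyl-only group also replaces the 3-amino-4-methoxyphenyl, and an 8.2-fold higher number from compound 1 to compound 3 (0.91 log units; beyond the scatter). Compound 4 carries only carbon in its new group, like compound 2, so a large rise is expected, estimated as a 20-fold higher number from compound 1 to compound 4 (1.30 log units; beyond the scatter). Compound 4 is therefore expected at 5000 nM, between 1500 nM and 15000 nM.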

Compound 4, half-maximal inhibitory concentration: 261 nM
Compound 4: the middle estimate sits 19-fold (1.28 log units) above what was measured, outside the stated range (below it).
By their numbers in this assay, from the lowest: compounds 1 and 4 (each within the scatter of the next); then compound 3. At a limit, above all of these: compound 2.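

In this assay the step to 3,4-dimethylphenyl gives a 1.0-fold higher number from compound 1 to compound 4 (0.02 log units; within the scatter) and so shows that, on this aromatic carbon, a group without the amino and methoxy substituents can match compound 1. A group of carbon only is thus no bar here, yet the choice of group still counts, with a 7.9-fold lower number from compound 3 to compound 4 (0.90 log units; beyond the scatter) and an at least 38-fold lower number from compound 2 to compound 4 (1.58 log units; beyond the scatter) as well. Compound 2 is held only at a limit: the limit of > 10000 nM in this assay, at which 1 of the 4 values shown sits.

From the compounds shown here alone, whether 4-methylphenyl, 3-aminophenyl or 3,4-dichlorophenyl in this place would keep the number of compound 1 stays open.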